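Urea in Place of the Cinnamamide: Cytotoxicity Expected Low

A few compounds are considered here, and "the series" means these few. Any claim that something is new, unique, unknown or untested is made for them only; others in the source may bear on it.

Compound 1 `COc1cc(NC(C)CCCNC(=O)/C(C)=C/c2ccccc2)c2ncccc2c1` was examined in an ADME assay on L6 cells (Rattus norvegicus) for cytotoxicity, read by resazurin assay, with a stated time of 70 h; a lower number here means a stronger inhibitor, a higher number a weaker inhibitor. Compound 1 gave only a limit there, > 100 ug/mL. Compound 2 `COc1cc(NC(C)CCCNC(=O)/C=C/c2cc(OC)c(OC)c(OC)c2)c2ncccc2c1` likewise gave a limit, > 100 ug/mL. Compound 3 `COc1cc(NC(C)CCCNC(=O)/C=C/c2cc(C(F)(F)F)cc(C(F)(F)F)c2)c2ncccc2c1` returned a number, 83.1 ug/mL. Compound 1 thus stands at the limit of > 100 ug/mL in this assay, at which 2 of the 3 values shown sit, so no order among these three can be read. The change to compound 4 `COc1cc(NC(C)CCCNC(=O)Nc2cccc(O)c2)c2ncccc2c1` is (3-hydroxyphenyl)amino in place of 1-methyl-2-phenylethenyl on a carbonyl carbon. No measured step of this kind exists among these compounds, so no precedent sets a direction; the step of a number no higher from compound 1 to compound 4 (the limit leaves the size open) is expected to be none beyond the scatter. Compound 4 is therefore estimated at 100 ug/mL, between 40 ug/mL and 250 ug/mL, and most probably reported again only as a limit.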

Compound 4, half-maximal inhibitory concentration: 38 ug/mL
Compound 4: middle estimate off by 2.6-fold (0.42 log units), on the high side; measured number outside the range, below it.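

In this assay, (3-hydroxyphenyl)amino in place of 1-methyl-2-phenylethenyl on a carbonyl carbon gives an at least 2.6-fold lower number from compound 1 to compound 4 (0.42 log units; beyond the scatter). Among these compounds, this is the only readable step here, and it shows that this position can move the number in this assay. Its full size stays open, as compound 1 carries only a limit: the limit of > 100 ug/mL in this assay, at which 2 of the 4 values shown sit.

On these data alone, whether the amino link or the hydroxy group carries the step remains open. A plain phenylamino group or a (3-methoxyphenyl)amino group on the same carbonyl carbon would separate the two.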